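Anilino to isopropylamino in a three-compound series

The source may report more compounds than this note shows. Statements on the series, on what has been measured and on what is new or still open speak of the compounds shown alone.

Measured in a functional assay on RAW264.7 cells (Mus musculus) for inhibition, read by Griess assay, with stated times of 1 h and 24 h; a higher number here means a weaker inhibitor, a lower number a stronger inhibitor:
compound 1 (`CCCc1nn(C)c2c(NCC(C)C)nc(/C=C/c3ccccc3)nc12`): 22100 nM
compound 2 (`CCCc1nn(C)c2c(Nc3ccccc3)nc(/C=C/c3ccccc3)nc12`): "not active" (no number reported)
compound 3 (`CCCc1nn(C)c2c(NCc3ccc(Cl)cc3)nc(/C=C/c3ccco3)nc12`): 9260 nM

Compound 2 has no place on the numerical scale: in this assay compound 2 is reported as "not active" (no number reported), with no number given. Any step starting from it therefore has an open size. The next compound to be read is compound 4 (`CCCc1nn(C)c2c(NC(C)C)nc(/C=C/c3ccccc3)nc12`), which is not yet measured. The structural change is isopropyl in place of phenyl on a nitrogen on an aromatic ring.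

In this assay a step towards stronger inhibition is expected, from no reported number to a measurable value, although its size cannot be fixed. This expectation rests on compound 1 at 22100 nM and compound 3 at 9260 nM, both of which gave numbers. A repeat of the outcome for compound 2 remains possible. For compound 4 the expected value is about 25000 nM, with an estimated range of 10000 nM to 60000 nM.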

Compound 4, half-maximal inhibitory concentration: 12200 nM
Compound 4: middle estimate off by 2.0-fold (0.31 log units), on the high side, and the stated range covers the measured number.
By their numbers in this assay, from the lowest: compounds 3, 4 and 1 (each within the scatter of the next, the first and the last beyond it).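

In this assay the nitrogen on an aromatic ring carries isopropyl in compound 4 and gives a measurable 12200 nM, whereas phenyl in compound 2 gives no number, so the step between them cannot be read and the change is known only as a move from no reported number to a value. Isopropyl in place of isobutyl gives a 1.8-fold lower number from compound 1 to compound 4 (0.26 log units; within the scatter), so the series does not separate these two groups at this position. Nothing shown explains either observation.

Going by these compounds, whether a longer chain such as n-hexyl, a cyclohexyl ring or a carboxylic acid on the chain would still give a number remains open. On these data alone, compound 3 differs from compound 1 and compound 4 in more than one place, so what its 4-chlorobenzyl group contributes alone also remains open.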